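Trimming the phenethylsulfanyl group down to methylsulfanyl

The compounds below may be only part of what the source reports. "The series", "measured", "known", "first", "only" and "open" are said of these compounds alone.

Compounds measured so far:
compound 1 `CSc1nc(=O)ccn1[C@@H]1O[C@H](COP(=O)(O)OP(=O)(O)O)[C@@H](O)[C@H]1O`, 4700 nM in an in vitro functional assay on 1321-N1 cells for agonist activity at P2Y purinoceptor 6 (Homo sapiens), read by scintillation proximity assay and inositol phosphate accumulation; a higher number here means that more compound is needed for the effect, a lower number that less compound is needed
compound 2 `Nc1nc(=O)ccn1[C@@H]1O[C@H](COP(=O)(O)O)[C@@H](O)[C@H]1O`, > 100000 nM
compound 3 `O=c1ccn([C@@H]2O[C@H](COP(=O)(O)O)[C@@H](O)[C@H]2O)c(SCCc2ccccc2)n1`, > 100000 nM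

Compound 3 gives only a limit in this assay, > 100000 nM, so its true value is not known as a number. Compound 2 also gives only a limit, > 100000 nM. The step that the two limits leave unreadable from compound 2 to compound 3 therefore cannot be read, because the limit of > 100000 nM in this assay, at which 2 of the 3 values shown sit, holds both ends. Compound 1 is the only one of the three that gives a number, 4700 nM.

The next compound, compound 4 `CSc1nc(=O)ccn1[C@@H]1O[C@H](COP(=O)(O)O)[C@@H](O)[C@H]1O`, differs from compound 3 by hydrogen in place of benzyl on a saturated chain carbon bound to a sulfur. For the measured compounds named here, no measured step covers this change directly; the one neighbouring step is unreadable, and compound 1 shares the methylsulfanyl group of compound 4 but carries a different phosphate chain. The expectation is that compound 4 stays weak, and the step of an at least 1.6-fold lower number from compound 3 to compound 4 (0.22 log units; that floor lies within the scatter) is estimated to stay close to the limit. Compound 4 is expected to give about 60000 nM, between 15000 nM and 200000 nM.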

Compound 4, half-maximal effective concentration: > 100000 nM
Compound 4: a limit, no number; the forecaster's own chance of this, stated with the estimate: 55%; middle value at least 1.6-fold (0.22 log units) from the limit.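

In this assay compound 4 gives > 100000 nM as a limit and not a number. For the compounds shown here, the one readable comparison keeps the methylsulfanyl group and changes only the phosphate chain: the shorter chain gives an at least 21-fold higher number from compound 1 to compound 4 (1.32 log units; beyond the scatter) and so counts for a great deal with this group in place. Trimming phenethylsulfanyl to methylsulfanyl shows no readable gain, and the steps to compound 4 from compound 2 and from compound 3 cannot be read, because both ends of each step rest on the same limit: the limit of > 100000 nM in this assay, at which 3 of the 4 values shown sit.

As far as these compounds go, the step along the phosphate chain has only a floor, so its true size stays open. Also open, from the compounds shown here alone, is whether an amino or ethylsulfanyl group on the aromatic carbon would give a number on the longer phosphate chain of compound 1.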